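The compounds below may be only part of what the source reports. "The series", "measured", "known", "first", "only" and "open" are said of these compounds alone.

Compound 1 `CC1(C)CCN(S(=O)(=O)c2ccc(NC(=O)c3ccc([N+](=O)[O-])o3)cc2)CC1` was measured in an ADME assay on IMR-90 cells (Homo sapiens) for cytotoxicity, read by CellTiter-Blue, with a stated time of 46 h; a higher number here means that more compound is needed for the effect, a lower number that less compound is needed. In this assay compound 1 gives > 25000 nM, which is a limit of the assay and not a number.
Compound 2 `O=C(Nc1ccc(S(=O)(=O)c2ccccc2)cc1)c1ccc([N+](=O)[O-])o1` was also measured. In this assay compound 2 gives > 25000 nM, again a limit of the assay.
Compound 3 `CC1(C)CCN(S(=O)(=O)c2ccc(NC(=O)c3cccc([N+](=O)[O-])c3)cc2)CC1` was measured as well. In this assay compound 3 gives > 25000 nM, once more a limit of the assay.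

Compound 3 therefore stands at the limit of the assay, and so do the other two measured compounds: the limit of > 25000 nM in this assay, at which 3 of the 3 values shown sit. Among the measured compounds shown here, no measured compound has a real number in this assay.

Compound 4 `CC1(C)CCN(S(=O)(=O)c2ccc(NC(=O)c3ccc(C(F)(F)F)o3)cc2)CC1` has not been measured. It differs from compound 3 in one place: 5-(trifluoromethyl)furan-2-yl in place of 3-nitrophenyl on a carbonyl carbon. For the measured compounds named here, the only measured step at the same place is a step that the two limits leave unreadable from compound 1 to compound 3, and the other measured step, a step that the two limits leave unreadable from compound 1 to compound 2, is equally unreadable. Neither step gives a size or direction, so there is no sign of a change beyond the scatter.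

Given that every measured compound sits at the limit, compound 4 is expected to sit there too, with the step that the limit leaves unreadable from compound 3 to compound 4 expected to be none beyond the scatter. For compound 4 the estimate in this assay is 30000 nM, with a range from 10000 nM to 100000 nM.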

Compound 4, half-maximal effective concentration: > 25000 nM
Compound 4: no number, only a limit; the forecaster's own chance of this, stated with the estimate: 85%; the middle value is on the limit's open side.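

In this assay compound 4 gives > 25000 nM, which is a limit of the assay and not a number. No step from compound 1 or compound 3 to compound 4 can therefore be read, and all the compounds share the same result: the limit of > 25000 nM in this assay, at which 4 of the 4 values shown sit.

The compounds shown leave open how much of any of them is needed for the effect, and whether changing groups on the shared core alters that amount at all.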